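Trifluoroethoxy for hydrogen on the arylpiperazine phenyl ring

The compounds below may be only part of what the source reports. "The series", "measured", "known", "first", "only" and "open" are said of these compounds alone.

Measured compounds:
compound 1, `COc1ccccc1N1CCN(CCCNc2ncc(C#N)cc2C(=O)N(C)C)CC1`, 20 nM
compound 2, `COc1ccccc1N1CCN(CCCNc2ccccc2C(=O)c2ccccc2)CC1`, 10 nM
compound 3, `CN(C)C(=O)c1cccnc1NCCCN1CCN(c2ccccc2)CC1`, 15.9 nM

In a functional assay on aorta for antagonist activity at Alpha-1D adrenergic receptor (Rattus norvegicus) (on this read-out higher numbers stand for weaker binding and lower numbers for tighter binding), compound 1 gives 20 nM, compound 2 gives 10 nM and compound 3 gives 15.9 nM. Compound 3 has the second highest of the three numbers; its gap to compound 1 and its gap to compound 2 are both within the usual scatter, so the three compounds cannot be ordered on this read-out.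

Compound 4, `CN(C)C(=O)c1cccnc1NCCCN1CCN(c2ccccc2OCC(F)(F)F)CC1`, is not yet measured in this assay. It differs from compound 3 in one place: 2,2,2-trifluoroethoxy in place of hydrogen on an aromatic carbon, on an aromatic carbon of a six-membered aromatic ring of carbon only, ortho to a large group. For the measured compounds named here, no measured pair shows this change alone, and compounds 1 and 2 carry a methoxy at the corresponding place with a different core, so they do not give a clean reference. The step from compound 3 to compound 4 is expected to be small, a 1.2-fold lower number from compound 3 to compound 4 (0.09 log units; within the scatter), not beyond the scatter in either direction. Compound 4 is therefore expected to give about 13 nM in this assay, within 4 nM to 40 nM.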

Compound 4, dissociation constant: 15.9 nM
Compound 4: middle estimate off by 1.2-fold (0.09 log units), on the low side; low and high end bracket the measured number.
By their numbers in this assay, from the lowest: compounds 2, 3, 4 and 1 (each within the scatter of the next).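

In this assay, 2,2,2-trifluoroethoxy in place of hydrogen on an aromatic carbon, ortho to a large group, gives no change at the digits printed from compound 3 to compound 4 (within the scatter). For the compounds shown here, this is the first step that changes a single place, and it shows that adding this group of 6 heavy atoms at this position leaves the read-out within the scatter, which the earlier compounds, with no one-place pair among them, could not show. No measurement of any property of these compounds bears on this result.

Methoxy at the corresponding place appears only on compound 1 and compound 2, whose cores differ from that of compound 3, so a step from hydrogen to methoxy on the shared core cannot be read. Also open, as far as these compounds go, is whether an amine, a carboxylic acid or a longer fluorinated alkoxy chain at this position would stay within the scatter on the shared core.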